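The source may report more compounds than this note shows. Statements on the series, on what has been measured and on what is new or still open speak of the compounds shown alone.

In a functional assay on HCT-116 cells (Homo sapiens) for cytotoxicity, read by MTT assay (on this read-out higher numbers stand for weaker inhibition and lower numbers for stronger inhibition), compound 1 `Cc1cc(O)c(C(=O)/C=C/c2ccccc2)c(=O)o1` gives > 100000 nM, which is a limit of the assay and not a number. Compound 2 `Cc1cc(O)c(C(=O)/C=C/c2ccc(N(C)C)cc2)c(=O)o1` gives > 100000 nM, again only a limit. Going by the values given here, compound 3 `Cc1cc(O)c(C(=O)/C=C/c2ccc([N+](=O)[O-])cc2)c(=O)o1` gives 65000 nM, the only true number so far. The other two compounds sit at the limit of > 100000 nM in this assay, at which 2 of the 3 values shown sit.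

Compound 4 `Cc1cc(O)c(C(=O)/C=C/c2ccc(C#N)cc2)c(=O)o1` has cyano in place of nitro on an aromatic carbon. The measured steps that bear on this change are those that introduce the nitro group or replace another group with it: an at least 1.5-fold lower number from compound 1 to compound 3 (0.18 log units; that floor lies within the scatter) and an at least 1.5-fold lower number from compound 2 to compound 3 (0.18 log units; that floor lies within the scatter). Both are only floors, and both floors lie within the scatter, so the standing of compound 3 against the other two remains weakly defined. Among the compounds with values here, no measured step shows what cyano does on this ring. No step beyond the scatter is therefore expected in this assay. The estimated step is a 1.2-fold higher number from compound 3 to compound 4 (0.09 log units; within the scatter). For compound 4 the estimated value is 80000 nM, with an expected range from 40000 nM to 150000 nM.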

Compound 4, half-maximal inhibitory concentration: 66000 nM
Estimate against measurement, compound 4: 1.2-fold (0.08 log units) above; measured number inside the range.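

In this assay, cyano in place of nitro on this aromatic carbon, para to a large group, leaves compound 3 and compound 4 indistinguishable (a 1.0-fold higher number from compound 3 to compound 4 (0.01 log units; within the scatter)). Cyano is thus a second group at this position, after nitro, that gives a true number rather than a limit, and its steps from the other two compounds are floors of the same size as those of nitro (an at least 1.5-fold lower number from compound 1 to compound 4 (0.18 log units; that floor lies within the scatter); an at least 1.5-fold lower number from compound 2 to compound 4 (0.18 log units; that floor lies within the scatter)). These two steps cannot be sized, and both floors stay within the scatter, because compound 1 and compound 2 rest on a limit: the limit of > 100000 nM in this assay, at which 2 of the 4 values shown sit.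

From the compounds shown here alone, what a halogen such as chlorine, a methoxy group or a carboxylic acid would do on this aromatic carbon stays open. Also open, going by these compounds, is whether any group here gives a step beyond the scatter.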